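The source may hold more compounds than are shown below. What is called first, only, known or untested is meant among the compounds shown, and "the series" means these compounds.

Measured so far in a functional assay on A549 cells (Homo sapiens) for antiproliferative activity, tested at 1 uM; a higher number here means more inhibition at the concentration tested (going by the name of the read-out), a lower number less inhibition:

compound 1 `COc1ccc(CO/N=C/c2c(C)nn(C)c2Oc2ccc(Cl)cc2)cc1` gives 43.9%
compound 2 `Cc1nn(C)c(Oc2ccccc2)c1/C=N/OCc1ccc(C(F)(F)F)cc1` gives 34.7%

Of these two numbers, the one for compound 2 is the smaller on paper, but the gap to compound 1 lies within the usual scatter of this kind of measurement, so the two compounds cannot be told apart on what is shown.

Compound 3 `Cc1nn(C)c(Oc2ccc(Cl)cc2)c1/C=N/OCc1ccc(C(F)(F)F)cc1` has not yet been measured. It differs from compound 2 in one place: chloro in place of hydrogen on an aromatic carbon. Going by the values given here, no pair of measured compounds shows this same change on its own, so there is no direct step to lean on. Compound 1 also carries a chloro on its phenoxy ring, but it differs from compound 2 in a second place as well, so its value does not isolate the effect of the chloro.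

With nothing stronger to go on, the step from compound 2 to compound 3 in this assay is expected to be small, upward if anything, and not clearly beyond the scatter: a number 5.3 percentage points higher from compound 2 to compound 3 (within the scatter). Compound 3 is therefore estimated at 40%, in a range from 22% to 58%.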

Compound 3, a percentage reported as inhibition, at one concentration (the size of the read-out at that concentration, not a potency): 50.9%
Beside the measured number, compound 3's estimate is 10.9 percentage points below it; the measured number falls inside the stated range.
By their numbers in this assay, from the lowest: compounds 2, 1 and 3 (each within the scatter of the next, the first and the last beyond it).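

In this assay, the phenoxy ring of compound 2 turns out to be a place where a small change can be read: phenoxy to 4-chlorophenoxy, with the rest of the molecule held fixed, gives a number 16.2 percentage points higher from compound 2 to compound 3 (beyond the scatter). Going by these compounds alone, at the other end of the molecule, with the 4-chlorophenoxy group kept, trifluoromethyl in place of methoxy on an aromatic carbon gives a number 7 percentage points higher from compound 1 to compound 3 (within the scatter), so this swap leaves the two compounds indistinguishable and the chloro is the only single change here with a readable effect. No measurement shown speaks to why the chloro has this effect.

The compounds shown leave open whether the gain belongs to chloro in particular, as none of them carries a fluoro, a bromo, a methyl or an amine at this place on the ring. On these data alone, it is also open whether the same step would appear with the methoxy group at the far end, and how it would translate into potency, as each number comes from a single tested concentration.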